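Cytotoxicity of a methylsulfinylphenyl amide in HEK cells

The source may report more compounds than this note shows. Statements on the series, on what has been measured and on what is new or still open speak of the compounds shown alone.

This account follows the change from compound 2 to compound 4 in a functional assay on HEK293 cells (Homo sapiens) for cytotoxicity; a higher number here means that more compound is tolerated, a lower number that less compound is tolerated. Compound 2 is `COc1ccc([C@H]2CC(=O)N(c3ccc(C)c(N)c3)C2)cc1OC1CCCC1` and in this assay compound 2 gives > 10000 nM, which is a limit of the assay and not a number. Compound 1, `COc1ccc([C@H]2CC(=O)N(c3cccc(N(C)C)c3)C2)cc1OC1CCCC1`, gives in this assay the limit > 10000 nM. Compound 3, `COc1ccc([C@H]2CC(=O)N(c3ccccc3C)C2)cc1OC1CCCC1`, gives in this assay the limit > 10000 nM. All three values therefore sit together at the limit of > 10000 nM in this assay, at which 3 of the 3 values shown sit, so compound 2 stands at that limit with the others. Compound 4 is `COc1ccc([C@H]2CC(=O)N(c3ccc([S+](C)[O-])cc3)C2)cc1OC1CCCC1`; it differs from compound 2 by a group of 9 heavy atoms (7 carbon, 1 oxygen, 1 sulfur; one six-membered aromatic ring of carbon only) in place of a group of 8 heavy atoms (7 carbon, 1 nitrogen; one six-membered aromatic ring of carbon only), on an amide-type nitrogen in a ring. Going by the values given here, the steps that bear on this change are a step that the two limits leave unreadable from compound 1 to compound 2, a step that the two limits leave unreadable from compound 1 to compound 3 and a step that the two limits leave unreadable from compound 2 to compound 3, none of which can be read in size. Among the compounds with values here, they show only that exchanging the group on the amide-type nitrogen in the ring has not brought any measurable toxicity. No step in either direction beyond the scatter is expected here, so the step that the limit leaves unreadable from compound 2 to compound 4 is estimated to be essentially flat. Compound 4 is expected to give 15000 nM in this assay, within 8000 nM to 50000 nM, most likely reported again as a limit.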

Compound 4, half-maximal cytotoxic concentration: 7510 nM
Beside the measured number, compound 4's estimate is 2.0-fold (0.30 log units) above it; the whole stated range lies above it.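

In this assay compound 4 gives a number, 7510 nM, where none of the other compounds shown gives one. The other three compounds stay at a limit of the assay, and the steps among them cannot be read: the limit of > 10000 nM in this assay, at which 3 of the 4 values shown sit.

The change to the group on the amide-type nitrogen in the ring gives an at least 1.3-fold lower number from compound 2 to compound 4 (0.12 log units; that floor lies within the scatter), an at least 1.3-fold lower number from compound 3 to compound 4 (0.12 log units; that floor lies within the scatter) and an at least 1.3-fold lower number from compound 1 to compound 4 (0.12 log units; that floor lies within the scatter), so this position can bring a cytotoxic concentration into the measurable range, though each step is only a floor.

As far as these compounds go, how far compound 4 truly lies from the other three compounds stays open. Also open, from the compounds shown here alone, is whether a methylsulfonylphenyl or a carboxyphenyl group on the same nitrogen would give a number in this assay or return to the limit.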